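The compounds below may be only part of what the source reports. "The series", "measured", "known", "first", "only" and "open" are said of these compounds alone.

Compound 1 `CSc1nc(NCCCCNc2ccnc3cc(Cl)ccc23)c(C#N)c(-c2cccc([N+](=O)[O-])c2)n1`: 100000 nM
Compound 2 `CSc1nc(NCCCCNc2ccnc3cc(Cl)ccc23)c(C#N)c(-c2ccc([N+](=O)[O-])cc2)n1`: 4000 nM
Compound 3 `COc1ccc(-c2nc(SC)nc(NCCCCNc3ccnc4cc(Cl)ccc34)c2C#N)cc1`: 20000 nM

In an ADME assay on HeLa cells (Homo sapiens) for cytotoxicity, read by microscopy (a higher number here means that more compound is tolerated, a lower number that less compound is tolerated), compound 3 stands second highest of the three numbers, separated from compound 1 by a 5.0-fold lower number from compound 1 to compound 3 (0.70 log units; beyond the scatter) and from compound 2 by a 5.0-fold higher number from compound 2 to compound 3 (0.70 log units; beyond the scatter). Compound 4 `COc1ccc(-c2nc(SC)nc(NCCCCNc3ccnc4cc(Cl)ccc34)c2C#N)cc1OC` differs from compound 3 by methoxy in place of hydrogen on an aromatic carbon. Within the data shown here, no measured step adds a methoxy where a hydrogen stood; the nearest comparison is a 5.0-fold higher number from compound 2 to compound 3 (0.70 log units; beyond the scatter), where one group replaced another and the number moved only modestly, while a 25-fold lower number from compound 1 to compound 2 (1.40 log units; beyond the scatter) shows that a shift of one group around the same ring can move this assay a great deal. A small step, or none beyond the scatter, is therefore expected in this assay. Compound 4 is expected to give 20000 nM, within 6000 nM to 60000 nM. The expected step is no change at the digits printed from compound 3 to compound 4 (within the scatter).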

Compound 4, minimum cytotoxic concentration: 100000 nM
The estimate for compound 4 lay 5.0-fold (0.70 log units) below the measured number; measured number above the stated range.
By their numbers in this assay, from the lowest: compound 2; then compound 3; then compounds 1 and 4 (each within the scatter of the next).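

In this assay, a second methoxy on the ring, ortho to the first, gives a 5.0-fold higher number from compound 3 to compound 4 (0.70 log units; beyond the scatter), so this hydrogen can be replaced with a measurable result. The 3,4-dimethoxyphenyl group also gives a 25-fold higher number from compound 2 to compound 4 (1.40 log units; beyond the scatter) and no change at the digits printed from compound 1 to compound 4 (within the scatter). Among these four compounds, compounds 1 and 4, which carry a group at this place, both have higher numbers than compounds 2 and 3, which carry hydrogen there.

Nothing here gives a reason for these steps. On these data alone, whether a hydroxyl or an amine at this place would behave like the methoxy remains open.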